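The compounds below may be only part of what the source reports. "The series", "measured", "known", "first", "only" and "open" are said of these compounds alone.

Measured so far:
Compound 1 `CC(=O)c1cc(-c2ccc(F)cc2)cc2cc(-c3ccccc3)[nH]c12`, in a functional assay on HeLa cells (Homo sapiens) for cytotoxicity, read by MTT assay, with a stated time of 2 days, tested at 100 uM (on this read-out lower numbers stand for a stronger effect and higher numbers for a weaker effect at the one concentration tested), compound 1 gives 24.8%.
Compound 2 `CC(=O)c1cc(-c2ccc(F)cc2)cc2cc(-c3ccc(F)cc3)[nH]c12`, compound 2 gives 9.31%.
Compound 3 `COc1ccc(-c2cc3cc(-c4ccccc4)cc(C(C)=O)c3[nH]2)cc1`, compound 3 gives 32.8%.

Compound 3 has the highest number of the three. It lies within the usual scatter of compound 1, so no order between those two can be claimed, but it stands clearly above compound 2. Compound 4 `COc1ccc(-c2cc3cc(-c4ccc(F)cc4)cc(C(C)=O)c3[nH]2)cc1` differs from compound 3 in one spot: fluoro in place of hydrogen on an aromatic carbon. The same change has been measured once before, in the pair a number 15.5 percentage points lower from compound 1 to compound 2 (beyond the scatter), a drop of modest size. Because a number 15.5 percentage points lower from compound 1 to compound 2 (beyond the scatter) came from an identical substitution, a comparable fall is expected here, a number 15.8 percentage points lower from compound 3 to compound 4 (beyond the scatter). Compound 4 is therefore estimated at 17%, with a likely range from 5% to 30%.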

Compound 4, a percentage reported as activity, at one concentration (the size of the read-out at that concentration, not a potency): 46.5%
Compound 4: middle estimate off by 29.5 percentage points, on the low side, and the stated range ends below it.
By their numbers in this assay, from the lowest: compound 2; then compounds 1 and 3 (each within the scatter of the next); then compound 4.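

Fluoro in place of hydrogen on an aromatic carbon has no fixed direction in this assay, and its effect depends on the core that carries it: the same change on two cores in this assay, a number 15.5 percentage points lower (beyond the scatter) from compound 1 to compound 2 and a number 13.7 percentage points higher (beyond the scatter) from compound 3 to compound 4, 29.2 percentage points apart, beyond the scatter of two such steps. On the core of compound 3, this change gives a number 13.7 percentage points higher from compound 3 to compound 4 (beyond the scatter), which means a weaker effect rather than a stronger one. Methoxy also goes with a weaker effect, both in place of fluoro, with a number 37.2 percentage points higher from compound 2 to compound 4 (beyond the scatter), and in place of hydrogen, with a number 21.7 percentage points higher from compound 1 to compound 4 (beyond the scatter).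

On these data alone, whether fluoro would lower or raise the number on further cores remains open. So does how an amine or a carboxylic acid would read at this position.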